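Notes on the benzylic substituent: compound 1 to compound 4

The source may hold more compounds than are shown below. What is called first, only, known or untested is meant among the compounds shown, and "the series" means these compounds.

Three compounds carry numbers in a functional assay on HOS cells (Homo sapiens) for inhibition, with a stated time of 72 h; on this read-out higher numbers stand for weaker inhibition and lower numbers for stronger inhibition. Compound 1 `NC1CCC(Nc2nc(NCc3ccc(Br)cc3)c3ncn(C4CCCC4)c3n2)CC1` gives 995 nM, the highest of the three. Compound 2 `OC1CCC(Nc2nc(NCc3ccc(-c4ccco4)nc3)c3ncn(C4CCCC4)c3n2)CC1` gives 180 nM, and compound 3 `NC1CCC(Nc2nc(NCc3ccc(-c4ccccc4O)nc3)c3ncn(C4CCCC4)c3n2)CC1` gives 14 nM; both of these stand beyond the scatter from compound 1. Compound 4 `Nc1ccccc1CNc1nc(NC2CCC(N)CC2)nc2c1ncn2C1CCCC1` is not yet measured in this assay. It differs from compound 1 in one place: 2-aminophenyl in place of 4-bromophenyl on a saturated chain carbon bound to a nitrogen on an aromatic ring. Among the compounds with values here, no measured pair shows this same change, so no step can be read directly, and the replacement present in compound 3 is a different one. Compound 4 is expected to give 500 nM, with a range of 120 nM to 2000 nM. The expected step is a 2.0-fold lower number from compound 1 to compound 4 (0.30 log units; within the scatter), toward stronger inhibition, of a size that may not clear the scatter.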

Compound 4, half-maximal inhibitory concentration: 2030 nM
Compound 4: the middle estimate sits 4.1-fold (0.61 log units) below what was measured; measured number outside the range, above it.
By their numbers in this assay, from the lowest: compound 3; then compound 2; then compound 1; then compound 4.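

Within the data shown here, replacing 4-bromophenyl with 2-aminophenyl on the saturated chain carbon gives a 2.0-fold higher number from compound 1 to compound 4 (0.31 log units; beyond the scatter) in this assay and is the first one-place change read at this position. It shows that the position responds to this replacement, with a modest move toward weaker inhibition. Nothing available explains the step.

Still open, from the compounds shown here alone, is whether the change follows from the amine itself or from where it sits on the phenyl ring. A 4-aminophenyl or 2-bromophenyl group on the same carbon would separate these two changes.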